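Working notes: bromo in place of 4-methylphenyl

The source may report more compounds than this note shows. Statements on the series, on what has been measured and on what is new or still open speak of the compounds shown alone.

Compound 1 `O=C(NO)c1ccc(/C=C/c2ccnc(-c3cccnc3)c2)cc1`: 5140 nM
Compound 2 `Cc1ccc(-c2cc(/C=C/c3ccc(C(=O)NO)cc3)ccn2)cc1`: 2390 nM

Going by the values given here, in a functional assay on HCT-116 cells (Homo sapiens) for antiproliferative activity, read by CellTiter-Glo, with a stated time of 72 h (on this read-out lower numbers stand for stronger inhibition and higher numbers for weaker inhibition), compound 2 gives 2390 nM, the lower of the two numbers, and compound 1 is its only neighbour. Next comes compound 3 `O=C(NO)c1ccc(/C=C/c2ccnc(Br)c2)cc1`, with bromo in place of 4-methylphenyl on an aromatic carbon, next to the ring nitrogen: bromo in place of 4-methylphenyl on an aromatic carbon. Among the compounds with values here, one measured step bears on this place: a 2.2-fold lower number from compound 1 to compound 2 (0.33 log units; beyond the scatter). It is modest and exchanges one aromatic ring for another. Within the data shown here, no measured compound lacks an aromatic ring here, so losing the ring is untested. A modest step towards a higher number is therefore expected in this assay, with a wide margin on both sides. The expected step is a 1.6-fold higher number from compound 2 to compound 3 (0.20 log units; within the scatter). For compound 3 the estimated value is 3800 nM, with an expected range of 1400 nM to 10500 nM.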

Compound 3, half-maximal inhibitory concentration: > 10000 nM
Compound 3 ended at the assay's limit (the forecaster's own chance of this, stated with the estimate: 5%); middle value at least 2.6-fold (0.42 log units) away from the limit.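

In this assay compound 3 gives > 10000 nM, which is a limit of the assay and not a number. Going by these compounds alone, this is the first reading at this place without an aromatic ring, whereas the earlier comparison only exchanged one aromatic ring for another; bromo in place of 4-methylphenyl gives an at least 4.1-fold higher number from compound 2 to compound 3 (0.62 log units; beyond the scatter). Bromo in place of pyridin-3-yl gives an at least 1.9-fold higher number from compound 1 to compound 3 (0.28 log units; that floor lies within the scatter), so the limit separates compound 3 clearly from compound 2 but does not separate it clearly from compound 1.

On these data alone, the true size of both steps stays unknown, since each rests on the limit. Also open, as far as these compounds go, is whether a non-aromatic group at this place, such as an amine or a piperidine ring, would behave like bromo or like the two aromatic rings.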